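The source may report more compounds than this note shows. Statements on the series, on what has been measured and on what is new or still open speak of the compounds shown alone.

Compound 1 `CCCCc1ccc(NC(=O)N[C@H](C)c2ccccc2)cc1` gives 32% in an ADME assay on the whole organism with Oryza sativa as the target, tested at 1 uM; on this read-out higher numbers stand for a weaker effect at the one concentration tested and lower numbers for a stronger effect. Compound 2 `CCCCCCCc1ccc(NC(=O)N[C@H](C)c2ccccc2)cc1` gives 100%. Compound 3 `CCCCCCCc1ccc(NC(=O)N[C@@H](C)c2ccccc2)cc1` gives 99%.

Compound 2 carries the highest number of the three. Compound 3 lies within the scatter of it, the step being a number 1 percentage points lower from compound 2 to compound 3 (within the scatter), and these two share all atoms and bonds, differing only in the configuration as drawn (the fact that compounds 2 and 3 differ only in the configuration as drawn). The step from compound 1 is large: a number 68 percentage points higher from compound 1 to compound 2 (beyond the scatter). Compound 4 `C[C@@H](NC(=O)Nc1ccc(I)cc1)c1ccccc1` has not yet been measured; it differs from compound 2 by iodo in place of heptyl on an aromatic carbon. Within the data shown here, the one measured step that bears on this change, a number 68 percentage points higher from compound 1 to compound 2 (beyond the scatter), shows that lengthening the chain raised the number strongly; here the entire heptyl chain is removed in favour of iodo, so a fall beyond the scatter is expected, a number 60 percentage points lower from compound 2 to compound 4 (beyond the scatter). Compound 4 is therefore estimated at 40%, within 15% to 80%.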

Compound 4, a percentage reported as activity, at one concentration (the size of the read-out at that concentration, not a potency): 91%
Compound 4: the middle estimate sits 51 percentage points below what was measured; measured number outside the range, above it.
By their numbers in this assay, from the lowest: compound 1; then compounds 4, 3 and 2 (each within the scatter of the next).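

In this assay, replacing heptyl with iodo on this aromatic carbon gives a number 9 percentage points lower from compound 2 to compound 4 (within the scatter), while replacing butyl with iodo gives a number 59 percentage points higher from compound 1 to compound 4 (beyond the scatter). A high number at this position therefore does not require a long chain, since the single iodine atom and the heptyl chain cannot be told apart here. Nothing in the data at hand explains why compound 1 stands apart from compound 4. On these data alone, it remains open whether an amine, a carboxylic acid or a pentyl chain on this aromatic carbon would give a number near that of compound 1 or near those of compounds 2 and 4.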